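The source may report more compounds than this note shows. Statements on the series, on what has been measured and on what is new or still open speak of the compounds shown alone.

In a functional assay on MCF7 cells (Homo sapiens) for antiproliferative activity (a lower number here means a stronger inhibitor, a higher number a weaker inhibitor), compound 1 (`O=c1oc2cc(O)ccc2c(-c2cccc(OCCCCCN3CCCCC3)c2)c1-c1ccccc1`) reads 15 nM and compound 2 (`O=c1oc2cc(O)ccc2c(-c2cccc(OCCCCN3CCCCC3)c2)c1-c1ccccc1`) reads 12 nM on the same scale. Compound 3 (`O=c1oc2cc(O)ccc2c(-c2ccc(OCCCCCN3CCCCC3)cc2)c1-c1ccccc1`) reads 335 nM in this assay and stands far above both. Compound 2 therefore sits level with compound 1 within the scatter, at the low end of the three numbers and well apart from compound 3.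

Still unmeasured is compound 4 (`O=c1oc2cc(O)ccc2c(-c2cccc(OCCCN3CCCCC3)c2)c1-c1ccccc1`). The change from compound 2 to compound 4 is piperidin-1-yl in place of (piperidin-1-yl)methyl on a saturated chain carbon, three bonds along the chain from an oxygen on an aromatic ring with piperidin-1-yl in place of (piperidin-1-yl)methyl on a saturated chain carbon, three bonds along the chain from an oxygen on an aromatic ring. This takes 4-(piperidin-1-yl)butyl to 3-(piperidin-1-yl)propyl.

For the measured compounds named here, one measured step bears on this: a 1.3-fold lower number from compound 1 to compound 2 (0.10 log units; within the scatter) is the same exchange made four bonds along the chain, and it lies within the scatter. Going by the values given here, compound 3 offers no step of this kind, so the support is a single pair. No step beyond the scatter is expected in this assay on that basis, with a slight allowance for a higher number. The estimated change a 1.3-fold higher number from compound 2 to compound 4 (0.10 log units; within the scatter) is expected to remain modest. For compound 4 the expected value is 15 nM with an estimated range of 6 nM to 45 nM around it.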

Compound 4, half-maximal inhibitory concentration: 9.5 nM
Beside the measured number, compound 4's estimate is 1.6-fold (0.20 log units) above it, and the stated range covers the measured number.
By their numbers in this assay, from the lowest: compounds 4, 2 and 1 (each within the scatter of the next); then compound 3.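

In this assay, the exchange of 4-(piperidin-1-yl)butyl for 3-(piperidin-1-yl)propyl, on a saturated chain carbon three bonds along the chain from an oxygen on an aromatic ring, gives a 1.3-fold lower number from compound 2 to compound 4 (0.10 log units; within the scatter), so a second exchange of this kind now stands beside a 1.3-fold lower number from compound 1 to compound 2 (0.10 log units; within the scatter), and both lie within the scatter. The wider exchange, piperidin-1-yl in place of 2-(piperidin-1-yl)ethyl at that same place, gives a 1.6-fold lower number from compound 1 to compound 4 (0.20 log units; within the scatter) and also lies within the scatter, so compound 1, compound 2 and compound 4 read as level and the chain length shows no measurable effect across these compounds in this assay. No measurement at hand accounts for this flat reading.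

Open, on these data alone, is how far the flat stretch runs: a 2-(piperidin-1-yl)ethyl chain or a chain longer than that of compound 1 could hold level or could part from it, and a morpholine or a dimethylamino group in place of the piperidine ring remains untested in these compounds. Also open is whether chain length stays as flat in the arrangement of compound 3, which reads 335 nM, since only one chain is shown there.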